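Permeability after swapping 2-methylphenyl for 6-methoxypyridin-3-yl

The source may hold more compounds than are shown below. What is called first, only, known or untested is meant among the compounds shown, and "the series" means these compounds.

- Compound 1 `Cc1nc2cc(-c3cccc(Oc4ccccc4)c3)nn2c(-c2cc(F)c3c(c2C)CCCO3)c1C(OC(C)(C)C)C(=O)O` with 472 nm/s
- Compound 2 `Cc1ccccc1-c1cccc(-c2cc3nc(C)c([C@H](OC(C)(C)C)C(=O)O)c(-c4cc(F)c5c(c4C)CCCO5)n3n2)c1` with 471 nm/s

In an ADME assay for permeability, using PAMPA, with a stated time of 4 h, at pH 7.4, tested at 100 uM (on this read-out lower numbers stand for lower permeability and higher numbers for higher permeability), compound 2 gives 471 nm/s and sits within the scatter of compound 1 at 472 nm/s on the two numbers available. Compound 3 `COc1ccc(-c2cccc(-c3cc4nc(C)c([C@H](OC(C)(C)C)C(=O)O)c(-c5cc(F)c6c(c5C)CCCO6)n4n3)c2)cn1` carries 6-methoxypyridin-3-yl in place of 2-methylphenyl on an aromatic carbon with the site meta to a large group. Among the compounds with values here, no measured step between compounds exists to guide the expectation. A small fall is expected, an estimated 1.4-fold lower number from compound 2 to compound 3 (0.14 log units; within the scatter) in this assay that may stay within the scatter. For compound 3 the expected value is 340 nm/s with an estimated range from 170 nm/s to 600 nm/s for now.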

Compound 3, apparent permeability: 514 nm/s
Compound 3: the middle estimate sits 1.5-fold (0.18 log units) below what was measured; low and high end bracket the measured number.
By their numbers in this assay, from the lowest: compounds 2, 1 and 3 (each within the scatter of the next).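

Within the data shown here, at this aromatic carbon, meta to a large group, 6-methoxypyridin-3-yl in place of 2-methylphenyl gives a 1.1-fold higher number from compound 2 to compound 3 (0.04 log units; within the scatter) in this assay as the first step that can be read. The entering group brings a ring hetero atom and 2 hydrogen-bond acceptors where the leaving group has 0, and the step still stays within the scatter. No measurement at hand offers a reason for this result. As far as these compounds go, both groups compared carry no net charge, so how an amine or a carboxylic acid on this carbon would read in this assay stays open.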